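The source may hold more compounds than are shown below. What is called first, only, known or untested is meant among the compounds shown, and "the series" means these compounds.

Of the compounds shown here, three have been measured in an assay on cells for inhibition of Voltage-dependent T-type calcium channel subunit alpha-1H (Homo sapiens), read by patch clamp; a higher number here means a weaker inhibitor, a lower number a stronger inhibitor. Compound 1 `O=C(CC1c2ccccc2N=C(SCCCCCN2CCCC2)N1c1ccc(-c2ccc(F)cc2)cc1)NCc1ccc(F)cc1` gives 4880 nM. Compound 2 `CN(C)CCCCCSC1=Nc2ccccc2C(CC(=O)NCc2ccc(F)cc2)N1c1ccc(-c2ccccc2)cc1` gives 3140 nM. Compound 3 `CN(C)CCCCCSC1=Nc2ccccc2C(CC(=O)NCc2ccc(F)cc2)N1c1ccccc1` gives 832000 nM, the highest number of the three, with compound 1 nearest and compound 2 furthest from it.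

Compound 4 `CN(C)CCCCCSC1=Nc2ccccc2C(CC(=O)NCc2ccc(F)cc2)N1c1ccc(-c2ccc(F)cc2)cc1` has not yet been measured. It differs from compound 3 by a single change, (4-fluorophenyl in place of hydrogen on an aromatic carbon), so the ring on the nitrogen of the shared core again carries a second aromatic ring, as in compound 1 and compound 2.

Among the measured compounds shown here, the one measured step that bears on this change is a 260-fold higher number from compound 2 to compound 3 (2.42 log units; beyond the scatter), which removed a phenyl from the same position. Going the other way, from a bare hydrogen to a 4-fluorophenyl, a step of similar size in the opposite direction is expected, so the number for compound 4 in this assay is expected to fall by a 240-fold lower number from compound 3 to compound 4 (2.38 log units; beyond the scatter). Compound 4 is therefore estimated at 3500 nM, with a range from 1200 nM to 10000 nM.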

Compound 4, half-maximal inhibitory concentration: 2760 nM
Beside the measured number, compound 4's estimate is 1.3-fold (0.10 log units) above it, within the range that was stated.
By their numbers in this assay, from the lowest: compounds 4, 2 and 1 (each within the scatter of the next); then compound 3.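

Putting a 4-fluorophenyl on the bare aromatic carbon gives a 300-fold lower number from compound 3 to compound 4 (2.48 log units; beyond the scatter) in this assay, so a large gain at this position appears with a second added ring, not only with the plain phenyl of compound 2. The fluoro on that added ring makes no readable difference, with a 1.1-fold lower number from compound 2 to compound 4 (0.06 log units; within the scatter), and neither does dimethylamino in place of pyrrolidin-1-yl at the end of the chain, with a 1.8-fold lower number from compound 1 to compound 4 (0.25 log units; within the scatter); both steps lie within the scatter. Nothing measured here explains why the added ring matters so much.

Going by these compounds, it remains open whether the gain needs an aromatic ring at all, or whether a cyclohexyl ring, or a single chlorine or methyl, at the same position would give it too. On these data alone, it is also open whether a carboxylic acid or a methoxy on the added ring would leave the number unchanged, as fluoro does.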